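Swapping the Aromatic Group of Compound 3

The source may report more compounds than this note shows. Statements on the series, on what has been measured and on what is new or still open speak of the compounds shown alone.

Four compounds share one core, and three have been measured in a functional assay on MCF7 cells (Homo sapiens) for antiproliferative activity, read by MTT assay, with a stated time of 72 h; on this read-out lower numbers stand for stronger inhibition and higher numbers for weaker inhibition. Compound 1 `CC1=CC[C@H]2[C@H](CC[C@]2(C)O)C(C)(C)[C@@H]1CC[C@H]1[C@]2(C)CC[C@H](OC(=O)CCC(=O)O)C(C)(C)O[C@H]2CC[C@@]1(C)O` gives > 50000 nM, which is a limit of the assay and not a number. Among the compounds with values here, compound 2 `CC1=CC[C@H]2[C@H](CC[C@]2(C)O)C(C)(C)[C@@H]1CC[C@H]1[C@]2(C)CC[C@H](OC(=O)c3cccc(C(F)(F)F)c3)C(C)(C)O[C@H]2CC[C@@]1(C)O` gives 37900 nM, and compound 3 `CC1=CC[C@H]2[C@H](CC[C@]2(C)O)C(C)(C)[C@@H]1CC[C@H]1[C@]2(C)CC[C@H](OC(=O)c3ccccc3[N+](=O)[O-])C(C)(C)O[C@H]2CC[C@@]1(C)O` gives 5200 nM, the lowest number so far. Compound 4 `CC1=CC[C@H]2[C@H](CC[C@]2(C)O)C(C)(C)[C@@H]1CC[C@H]1[C@]2(C)CC[C@H](OC(=O)c3ccc(C(F)(F)F)c(F)c3)C(C)(C)O[C@H]2CC[C@@]1(C)O` carries 3-fluoro-4-(trifluoromethyl)phenyl in place of 2-nitrophenyl on a carbonyl carbon. The closest measured change swapped 3-(trifluoromethyl)phenyl for 2-nitrophenyl, giving a 7.3-fold lower number from compound 2 to compound 3 (0.86 log units; beyond the scatter), beyond the scatter. Compound 4 again carries a trifluoromethyl group, so much of a 7.3-fold lower number from compound 2 to compound 3 (0.86 log units; beyond the scatter) is expected to reverse. The expected move, toward weaker inhibition, is a 3.8-fold higher number from compound 3 to compound 4 (0.59 log units; beyond the scatter). For compound 4 the estimate is 20000 nM, within a range of 7000 nM to 50000 nM.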

Compound 4, half-maximal inhibitory concentration: > 50000 nM
Compound 4: no number, only a limit; the forecaster's own chance of this, stated with the estimate: 15%; at least 2.5-fold (0.39 log units) between middle value and limit.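

In this assay compound 4 gives > 50000 nM, which is a limit of the assay and not a number. At this carbonyl carbon, replacing 2-nitrophenyl with 3-fluoro-4-(trifluoromethyl)phenyl costs much of the inhibition, with an at least 9.6-fold higher number from compound 3 to compound 4 (0.98 log units; beyond the scatter), whereas adding to the trifluoromethyl-bearing ring shows no clear change, with an at least 1.3-fold higher number from compound 2 to compound 4 (0.12 log units; that floor lies within the scatter). The step between compound 1 and compound 4 cannot be read, and the ceiling now limits this series: the limit of > 50000 nM in this assay, at which 2 of the 4 values shown sit.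

Going by these compounds, whether the lower number of compound 3 belongs to the nitro group itself stays open. An amine or a nitrile on the same phenyl ring would bear on that question.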